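The source may hold more compounds than are shown below. What is called first, only, known or untested is meant among the compounds shown, and "the series" means these compounds.

Of the compounds shown here, three sharing one core have been measured in an assay on isolated protein for binding affinity to 5-hydroxytryptamine receptor 1B (Rattus norvegicus); a lower number here means a stronger inhibitor, a higher number a weaker inhibitor. Compound 1 `c1ccc2c(c1)CC2CCCN1CCN(c2cccc3c2OCCO3)CC1` gives 646 nM. Compound 2 `c1ccc2c(c1)CCC2CCN1CCN(c2cccc3c2OCCO3)CC1` gives 417 nM. Compound 3 `C1=C(CCN2CCN(c3cccc4c3OCCO4)CC2)Cc2ccccc21` gives 933 nM; set against compound 2, this is a 2.2-fold higher number from compound 2 to compound 3 (0.35 log units; beyond the scatter), while set against compound 1 the gap is a 1.4-fold higher number from compound 1 to compound 3 (0.16 log units; within the scatter), so compound 3 sits at the high end of the three but is separated clearly only from compound 2.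

Compound 4 `Clc1cccc2c1CC2CCN1CCN(c2cccc3c2OCCO3)CC1` differs from compound 3 in one place: a group of 9 heavy atoms (8 carbon, 1 chlorine; one four-membered non-aromatic ring of carbon only, one six-membered aromatic ring of carbon only) in place of a group of 9 heavy atoms (9 carbon; one five-membered non-aromatic ring of carbon only, one six-membered aromatic ring of carbon only), on a saturated chain carbon, two bonds along the chain from an amine nitrogen in a ring. For the measured compounds named here, the steps that bear on this are the exchanges of the ring pair at the same place, namely a 1.5-fold lower number from compound 1 to compound 2 (0.19 log units; within the scatter), a 1.4-fold higher number from compound 1 to compound 3 (0.16 log units; within the scatter) and a 2.2-fold higher number from compound 2 to compound 3 (0.35 log units; beyond the scatter); all three are small. Going by the values given here, no measured step shows the effect of adding chlorine to this ring pair, so that part is an open question. Compound 4 is therefore expected to land near compounds 1 and 2, a step of a 1.9-fold lower number from compound 3 to compound 4 (0.27 log units; within the scatter), with the estimate for compound 4 in this assay at 500 nM, between 200 nM and 1500 nM.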

Compound 4, inhibition constant: 708 nM
Compound 4: the middle estimate sits 1.4-fold (0.15 log units) below what was measured; the measured number falls inside the stated range.
By their numbers in this assay, from the lowest: compounds 2, 1, 4 and 3 (each within the scatter of the next, the first and the last beyond it).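

In this assay, placing the chlorine-bearing group with its four-membered ring on this saturated chain carbon, two bonds along the chain from an amine nitrogen in a ring, gives three steps (a 1.3-fold lower number from compound 3 to compound 4 (0.12 log units; within the scatter)) and (a 1.7-fold higher number from compound 2 to compound 4 (0.23 log units; within the scatter)) and (a 1.1-fold higher number from compound 1 to compound 4 (0.04 log units; within the scatter)). For the compounds shown here, all three lie within the scatter, so compound 4 cannot be told apart from any of the earlier compounds, and a chlorine-bearing group fits at this position without a clear shift in the number. No other measurement is available here to explain this result.

Chlorine appears in compound 4 alone, so these compounds cannot show whether the same reading would hold for another atom or group there, such as fluorine, methoxy or an amine. As far as these compounds go, the effect of a different attachment point for the chlorine on the ring pair also remains open.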